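Series notes: iodo for pyridin-2-yl at the aromatic carbon

A few compounds are considered here, and "the series" means these few. Any claim that something is new, unique, unknown or untested is made for them only; others in the source may bear on it.

Compound 2 `O=C1Nc2ccc(-c3ccccn3)cc2/C1=C/c1cc(Cl)c(O)c(Cl)c1` gives 7.3% in an assay on HeLa cells for inhibition of Kinesin-like protein KIF15 (Homo sapiens), read by microscopy, with stated times of 2 s and 20 s, tested at 750 nM (a higher number here means more inhibition at the concentration tested (going by the name of the read-out), a lower number less inhibition), the higher of the two numbers shown; compound 1 `O=C1Nc2ccc(C(=O)NCc3ccccc3)cc2/C1=C/c1cc(Cl)c(O)c(Cl)c1` gives -24%, and the step of a number 31.3 percentage points higher from compound 1 to compound 2 (beyond the scatter) is the only one measured. Compound 3 `O=C1Nc2ccc(I)cc2/C1=C/c1cc(Cl)c(O)c(Cl)c1` differs from compound 2 by iodo in place of pyridin-2-yl on an aromatic carbon. For the measured compounds named here, no measured step puts iodo in place of pyridin-2-yl, so that step gives no guide, and no change beyond the scatter is expected; a number 0.7 percentage points higher from compound 2 to compound 3 (within the scatter) is the estimated step. Compound 3 is expected to give about 8%, in the range -25% to 40%.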

Compound 3, a percentage reported as inhibition, at one concentration (the size of the read-out at that concentration, not a potency): 15%
Beside the measured number, compound 3's estimate is 7 percentage points below it; the range from low to high includes it.
By their numbers in this assay, from the lowest: compound 1; then compounds 2 and 3 (each within the scatter of the next).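

At this aromatic carbon, iodo, a single atom with no ring and no hydrogen-bond acceptor, cannot be told apart from pyridin-2-yl in this assay (a number 7.7 percentage points higher from compound 2 to compound 3 (within the scatter)). Iodo in place of benzylcarbamoyl gives a large step (a number 39 percentage points higher from compound 1 to compound 3 (beyond the scatter)), so both replacements now leave compound 1 lowest, and the gap goes with benzylcarbamoyl rather than with one particular replacement. No measurement at hand gives a cause for these steps. Open, as far as these compounds go, is whether an amine, a carboxylic acid or a smaller halogen such as fluoro at this carbon would move the number beyond the scatter from compound 3. Also open, from the compounds shown here alone, is whether any group here gives strong inhibition.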